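Swapping a Methoxy for Chloro on the Anilide Ring

The compounds below may be only part of what the source reports. "The series", "measured", "known", "first", "only" and "open" are said of these compounds alone.

Compound 1 `O=C(Nc1ccccc1)C1CCN(C/C=C/c2ccccc2)CC1` gives 69700 nM in a functional assay on A549 cells (Homo sapiens) for inhibition, read by MTT assay, with a stated time of 72 h; a lower number here means a stronger inhibitor, a higher number a weaker inhibitor. Compound 2 `COc1cccc(NC(=O)C2CCN(C/C=C/c3ccccc3)CC2)c1` gives 50500 nM in this assay, the lowest of the two numbers, though the step of a 1.4-fold lower number from compound 1 to compound 2 (0.14 log units; within the scatter) lies within the scatter. Compound 3 `O=C(Nc1cccc(Cl)c1)C1CCN(C/C=C/c2ccccc2)CC1` differs from compound 2 by chloro in place of methoxy on an aromatic carbon. Among the compounds with values here, no measured step involves chloro, and the one step on this aromatic carbon stayed within the scatter, so the step of a 1.3-fold lower number from compound 2 to compound 3 (0.10 log units; within the scatter) is expected to be small and of uncertain direction. Compound 3 is therefore estimated at 40000 nM, with a range from 15000 nM to 100000 nM.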

Compound 3, half-maximal inhibitory concentration: 19100 nM
Beside the measured number, compound 3's estimate is 2.1-fold (0.32 log units) above it; the measured number falls inside the stated range.
By their numbers in this assay, from the lowest: compound 3; then compounds 2 and 1 (each within the scatter of the next).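

At this aromatic carbon, chloro in place of methoxy gives a 2.6-fold lower number from compound 2 to compound 3 (0.42 log units; beyond the scatter) in this assay and so moves the number beyond the scatter, which methoxy in place of hydrogen did not do. Chloro in place of hydrogen gives a 3.6-fold lower number from compound 1 to compound 3 (0.56 log units; beyond the scatter) as well, so the identity of the group at this carbon does matter here. Nothing available explains why chloro and methoxy differ. As far as these compounds go, whether bromo, trifluoromethyl or an amine at this carbon would lower the number further remains open. So does whether chloro on another carbon of this ring would give a similar step.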